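Replacing one aromatic ring in a slowly cleared compound

The source may hold more compounds than are shown below. What is called first, only, known or untested is meant among the compounds shown, and "the series" means these compounds.

Measured so far (an ADME assay on microsomes from liver (Homo sapiens) for metabolic stability; on this read-out lower numbers stand for slow clearance and higher numbers for fast clearance):
Compound 1 `Cc1ccc2[nH]c(C(=O)N[C@H]3CN(S(=O)(=O)c4ccccc4)C[C@@H]3C(=O)NC[C@H]3CCCN3C)cc2c1` (22 mL.min-1.g-1)
Compound 2 `Cc1ccc2[nH]c(C(=O)N[C@H]3CCN(S(=O)(=O)c4ccccc4Cl)C[C@@H]3C(=O)N[C@H]3CCCNC3)cc2c1` (25 mL.min-1.g-1)
Compound 3 `Cc1csc(C(=O)N[C@H]2CN(S(=O)(=O)c3ccccc3)C[C@@H]2C(=O)N[C@H]2CCCNC2)n1` (9.1 mL.min-1.g-1)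

Among these three, compound 3 has the lowest value (9.1 mL.min-1.g-1), and compound 1 and compound 2 both lie beyond the usual scatter from it. Compound 4 (`O=C(N[C@H]1CN(S(=O)(=O)c2ccccc2)C[C@@H]1C(=O)N[C@H]1CCCNC1)c1cc(C2CC2)n[nH]1`) differs from compound 3 in one place: 3-cyclopropyl-1H-pyrazol-5-yl stands in place of 4-methyl-1,3-thiazol-2-yl on a carbonyl carbon (3-cyclopropyl-1H-pyrazol-5-yl in place of 4-methyl-1,3-thiazol-2-yl on a carbonyl carbon). For the measured compounds named here, no two measured compounds differ in only one place, so this swap has no direct precedent here. Going by the values given here, the only guide is the spread of values: compound 1 (22 mL.min-1.g-1) and compound 2 (25 mL.min-1.g-1) show how far numbers run in this small set, although each differs from compound 3 in several places. In this assay a small upward step is expected, and the estimated step (a 1.4-fold higher number from compound 3 to compound 4 (0.15 log units; within the scatter)) stays within the scatter. Compound 4 is estimated at 13 mL.min-1.g-1 (expected range 5 mL.min-1.g-1 to 28 mL.min-1.g-1).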

Compound 4, intrinsic clearance in microsomes: < 3 mL.min-1.g-1
Compound 4 gave a limit, no number (the forecaster's own chance of this, stated with the estimate: 3%); middle value at least 4.3-fold (0.63 log units) from the limit.
By their numbers in this assay, from the lowest: compound 3; then compounds 1 and 2 (each within the scatter of the next). At a limit, below all of these: compound 4.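

In this assay, the group on this carbonyl carbon clearly matters: 3-cyclopropyl-1H-pyrazol-5-yl in place of 4-methyl-1,3-thiazol-2-yl gives an at least 3.0-fold lower number from compound 3 to compound 4 (0.48 log units; beyond the scatter). The earlier compounds shown here differ from one another in several places, so they could not tie a change in clearance to any single group, whereas this pair differs in one place only. Compound 4 stands at a limit of the assay, not at a number: the limit of < 3 mL.min-1.g-1 in this assay, at which 1 of the 4 values shown sits.

The compounds shown do not separate the part played by the cyclopropyl ring from that of the pyrazole ring, which a pyrazole carrying a methyl group instead of the cyclopropyl would help to do. For the compounds shown here, it also remains open whether the same swap would have a similar effect with the other amide side chain, the one in compound 1.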